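Changing the aryl group on the triazole: compound 4

This account rests on a few compounds, and the source may have more. Where it says the series, first, only, none or still open, it means among the compounds named here.

Compound 1 `N#CC1=C(N)Oc2c(N)cc3nc4ccccc4nc3c2C12C(=O)N(Cc1cnnn1-c1ccccc1Cl)c1ccccc12` gives 29800 nM in a functional assay on A549 cells (Homo sapiens) for antiproliferative activity, read by MTT assay, with a stated time of 48 h; a higher number here means a weaker inhibitor, a lower number a stronger inhibitor.
Compound 2 `CCOc1ccc(-n2nncc2CN2C(=O)C3(C(C#N)=C(N)Oc4c(N)cc5nc6ccccc6nc5c43)c3ccccc32)cc1` gives only a limit in this assay, > 50000 nM.
Compound 3 `CCc1cccc(C)c1-n1nncc1CN1C(=O)C2(C(C#N)=C(N)Oc3c(N)cc4nc5ccccc5nc4c32)c2ccccc21` gives only a limit in this assay, > 50000 nM.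

Compound 3 therefore stands at the point where no number is reported, (the limit of > 50000 nM in this assay, at which 2 of the 3 values shown sit); nothing more is known of its value. Compound 4 `Cc1ccc(Cl)cc1-n1nncc1CN1C(=O)C2(C(C#N)=C(N)Oc3c(N)cc4nc5ccccc5nc4c32)c2ccccc21` differs from it only in the aryl group on the triazole: 5-chloro-2-methylphenyl in place of 2-ethyl-6-methylphenyl on an aromatic nitrogen. Within the data shown here, the steps that bear on such a change are an at least 1.6-fold higher number from compound 1 to compound 2 (0.22 log units; that floor lies within the scatter) and an at least 1.6-fold higher number from compound 1 to compound 3 (0.22 log units; that floor lies within the scatter), while a step that the two limits leave unreadable from compound 2 to compound 3. These give no readable direction beyond the scatter. Compound 4 is expected to stay close to the limit, with an estimated value of 45000 nM in this assay, ranging from 20000 nM to 100000 nM. That estimate means an at least 1.1-fold lower number from compound 3 to compound 4 (0.04 log units; that floor lies within the scatter) is expected.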

Compound 4, half-maximal inhibitory concentration: > 50000 nM
Compound 4: only a limit was reported (the forecaster's own chance of this, stated with the estimate: 55%); middle value at least 1.1-fold (0.04 log units) from the limit.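

Compound 4 shows that a chlorine on the aryl group, which compound 1 also carries, does not by itself give a number in this assay: the limit of > 50000 nM in this assay, at which 3 of the 4 values shown sit.

Among these compounds, the one step that can be read is an at least 1.6-fold higher number from compound 1 to compound 4 (0.22 log units; that floor lies within the scatter). The steps from compound 2 and from compound 3 to compound 4 cannot be read, as both ends are limits.

Still open, from the compounds shown here alone, is whether any group at this position gives a value clearly apart from that of compound 1. An aminophenyl or carboxyphenyl group, or a pyridyl ring in place of the phenyl, could test this.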